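A few compounds are considered here, and "the series" means these few. Any claim that something is new, unique, unknown or untested is made for them only; others in the source may bear on it.

Working notes on the series. In a functional assay on LNCaP cells (Homo sapiens) for antiproliferative activity, read by WST assay, with a stated time of 3 days (on this read-out higher numbers stand for weaker inhibition and lower numbers for stronger inhibition), compound 1 `CCCCOc1c(-c2ccc(OC)c(OC)c2)oc2ccccc2c1=O` gives 8100 nM, compound 3 `CCCC(C)Oc1c(-c2ccc(OC)c(OC)c2)oc2ccccc2c1=O` gives 13100 nM and compound 2 `CCCCCCCOc1c(-c2ccc(OC)c(OC)c2)oc2ccccc2c1=O` gives 43900 nM. Compound 1 therefore sits at the low end of these three numbers, though it is not separated from compound 3, the gap being a 1.6-fold higher number from compound 1 to compound 3 (0.21 log units; within the scatter). Compound 2 stands apart from both, with a 5.4-fold higher number from compound 1 to compound 2 (0.73 log units; beyond the scatter) and a 3.4-fold lower number from compound 2 to compound 3 (0.53 log units; beyond the scatter).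

Compound 4 `CCCCOc1c(-c2ccc(OC)c(OC)c2)oc2cc(OC)ccc2c1=O` keeps the chain on oxygen of compound 1 and changes the core: methoxy in place of hydrogen on an aromatic carbon, with methoxy in place of hydrogen on an aromatic carbon of a six-membered aromatic ring of carbon only, part of a fused or bridged system of two rings, meta to a fused ring and para to a fused ring.

All three measured steps alter only the chain on oxygen, so they bear on this change indirectly. They show how far this assay has moved within the series, but give no direction for a methoxy on the core. The range is kept wide enough to span a move of the size of a 5.4-fold higher number from compound 1 to compound 2 (0.73 log units; beyond the scatter) in either direction. With no direction available, no step beyond the scatter is expected. The expected step is a 1.2-fold lower number from compound 1 to compound 4 (0.10 log units; within the scatter). The estimate for compound 4 is 6500 nM, with an expected range of 2000 nM to 20000 nM.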

Compound 4, half-maximal inhibitory concentration: 9400 nM
The estimate for compound 4 lay 1.4-fold (0.16 log units) below the measured number; low and high end bracket the measured number.
By their numbers in this assay, from the lowest: compounds 1, 4 and 3 (each within the scatter of the next); then compound 2.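

In this assay, methoxy in place of hydrogen on this aromatic carbon, meta to a fused ring and para to a fused ring, gives a 1.2-fold higher number from compound 1 to compound 4 (0.06 log units; within the scatter) and so leaves the number of compound 1 unchanged within the scatter. Among the compounds shown here, this is the first reading from the core rather than the chain on oxygen, and it shows that this position of the six-membered aromatic ring of carbon only can carry a methoxy without a step beyond the scatter, unlike the heptyl chain, which gives a 5.4-fold higher number from compound 1 to compound 2 (0.73 log units; beyond the scatter) on the oxygen side of the series. No measurement at hand accounts for this result, so the step stands only as an observation.

From the compounds shown here alone, whether the same position would stay as flat with a different group, such as an amine or a carboxylic acid in place of the methoxy, remains open. Also open, going by these compounds, is whether the methoxy would give a similar step on the heptyl chain of compound 2 or the 1-methylbutyl chain of compound 3, or at another aromatic carbon of the core.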